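The source may hold more compounds than are shown below. What is called first, only, known or untested is meant among the compounds shown, and "the series" means these compounds.

Compound 1 `CCC/N=C(/NC#N)NCCCn1nc(-c2ccccc2)ccc1=O` was tested in a functional assay on the whole organism (stomach) with Rattus norvegicus as the target (on this read-out lower numbers stand for an effect already at smaller amounts and higher numbers for an effect only at larger amounts of compound), and gave 100 mg/kg. Among the two compounds measured so far this is the highest number; its nearest neighbour is compound 2 `CN(C)/C(=N/CCCCCn1nc(-c2ccccc2)ccc1=O)NC#N`, which in this assay gives 81.5 mg/kg, a value within the scatter of compound 1, so no order between the two can be read from these data. Compound 3 `N#CNC(=N)NCCCn1nc(-c2ccccc2)ccc1=O` has not yet been tested. Within the data shown here, it differs from compound 1 in one place: a group of 5 heavy atoms (2 carbon, 3 nitrogen; no ring) in place of a group of 8 heavy atoms (5 carbon, 3 nitrogen; no ring), on an amine nitrogen With no measured pair showing the effect of such a change on an amine nitrogen, the account rests on compound 1 alone, and the step of no change at the digits printed from compound 1 to compound 3 (within the scatter) is expected to stay within the scatter, with no clear direction. Compound 3 is therefore estimated to give about 100 mg/kg in this assay, with a range from 40 mg/kg to 250 mg/kg.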

Compound 3, dose for half-maximal effect: > 100 mg/kg
Compound 3 ended at the assay's limit; the forecaster's own chance of this, stated with the estimate: 15%; the middle value sits exactly at the limit.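

In this assay compound 3 gives > 100 mg/kg, which is a limit of the assay and not a number. Putting the group of 5 heavy atoms in place of the group of 8 heavy atoms on the amine nitrogen gives a number no lower from compound 1 to compound 3 (the limit leaves the size open), the only step shown at this position, so the smaller group brings no lower number on this read-out, though how far the value moves cannot be told. The reading of this step is bounded by the assay itself: the limit of > 100 mg/kg in this assay, at which 1 of the 3 values shown sits.

Among these compounds, compound 2 differs from compound 1 in more than one place and so adds no second step at this position. On these data alone, what a longer chain, a cyclic amine or an aromatic ring on this nitrogen would give remains open, as does the true value of compound 3.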